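The source may hold more compounds than are shown below. What is called first, only, known or untested is meant among the compounds shown, and "the series" means these compounds.

Working notes on the series

Compound 1 `O=C(CN1C(=O)c2ccccc2C1=O)NN1C(=O)CSC1c1ccccc1O` gives 1.46 in a physicochemical assay for lipophilicity, in phosphate buffer, measured as octanol-water partition, with a stated time of 24 h; a higher number here means a more lipophilic compound, a lower number a more polar compound. On the numbers shown it stands second highest of three: compound 2 `COc1cc(C2SCC(=O)N2NC(=O)CN2C(=O)c3ccccc3C2=O)ccc1O` gives 1.31, and the step of a number 0.15 log units lower from compound 1 to compound 2 (within the scatter) lies within the scatter, whereas compound 3 `O=C(CN1C(=O)c2ccccc2C1=O)NN1C(=O)CSC1c1c(F)cccc1Cl` gives 3.79, with a number 2.33 log units higher from compound 1 to compound 3 (beyond the scatter) and a number 2.48 log units higher from compound 2 to compound 3 (beyond the scatter) both well beyond it.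

Compound 4 `O=C(CN1C(=O)c2ccccc2C1=O)NN1C(=O)CSC1c1ccco1` has not yet been measured. It differs from compound 1 at one place: furan-2-yl in place of 2-hydroxyphenyl on a saturated ring carbon. The measured steps at that same saturated ring carbon bear on this: the exchange of 2-hydroxyphenyl for 4-hydroxy-3-methoxyphenyl moved nothing beyond the scatter, while the exchange for 2-chloro-6-fluorophenyl moved the value a great deal. Going by the values given here, no measured step removes the hydroxyl donor without adding halogens, so the expectation rests on the size of the leaving and entering groups alone, and a small step is expected, a number 0.04 log units higher from compound 1 to compound 4 (within the scatter), with neither direction favoured beyond the scatter. Compound 4 is therefore estimated at 1.5, in the range 0.9 to 2.1.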

Compound 4, partition coefficient: 1.13
For compound 4 the middle estimate is 0.37 log units above the measured one; measured number inside the range.
By their numbers in this assay, from the lowest: compounds 4, 2 and 1 (each within the scatter of the next, the first and the last beyond it); then compound 3.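

At this saturated ring carbon in this assay, furan-2-yl in place of 2-hydroxyphenyl gives a number 0.33 log units lower from compound 1 to compound 4 (beyond the scatter) and so shows that an exchange losing the hydrogen-bond donor without bringing in halogens can move the value past the scatter, though only modestly. Set against 4-hydroxy-3-methoxyphenyl, the same group gives a number 0.18 log units lower from compound 2 to compound 4 (within the scatter) and against 2-chloro-6-fluorophenyl it gives a number 2.66 log units lower from compound 3 to compound 4 (beyond the scatter) so that, among the four groups at this carbon, 2-chloro-6-fluorophenyl alone produces large steps. No measurement is available that explains either step.

The compounds shown leave open where a phenyl carrying a single chlorine, or one carrying a carboxylic acid, would fall at this carbon. They also leave open whether the large steps to compound 3 belong to the chlorine, the fluorine or the two together.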